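A few compounds are considered here, and "the series" means these few. Any claim that something is new, unique, unknown or untested is made for them only; others in the source may bear on it.

Compound 1 `CC(/C=N/Nc1ccc([N+](=O)[O-])cc1)=N\NC(=O)c1ccccc1Cl` in a functional assay on cells (Splenocyte, Mus musculus, strain BALB/c) for inhibition, read by scintillation counting and thymidine incorporation, with a stated time of 72 h (on this read-out higher numbers stand for weaker inhibition and lower numbers for stronger inhibition), gives > 12000 nM, which is a limit of the assay and not a number.
Compound 2 `CC(/C=N/Nc1ccc([N+](=O)[O-])cc1)=N\NC(=O)c1ccccc1` in this assay gives > 12000 nM, again a limit rather than a number.
Compound 3 `CC(/C=N/Nc1ccc([N+](=O)[O-])cc1)=N\NC(=O)c1ccc(N)cc1` in this assay gives > 12000 nM, again a limit rather than a number.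

Compound 3 therefore stands where every measured compound stands, at the limit of > 12000 nM in this assay, at which 3 of the 3 values shown sit. Compound 4 `CC(/C=N/Nc1ccc([N+](=O)[O-])cc1)=N\NC(=O)c1ccc(Cl)cc1` differs from compound 3 by chloro in place of amino on an aromatic carbon. Among the compounds with values here, no measured step bears directly on this change, and the steps a step that the two limits leave unreadable from compound 1 to compound 2, a step that the two limits leave unreadable from compound 1 to compound 3 and a step that the two limits leave unreadable from compound 2 to compound 3 all run between limits, so their sizes cannot be read. With every value at the same limit, no step beyond the scatter can be expected in this assay in either direction; the numbers only suggest that compound 4 will most likely also stay at a limit. Compound 4 is expected near 15000 nM, in the range 5000 nM to 50000 nM, an expected step that the limit leaves unreadable from compound 3 to compound 4.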

Compound 4, half-maximal inhibitory concentration: 4200 nM
Compound 4: the middle estimate sits 3.6-fold (0.55 log units) above what was measured, outside the stated range (below it).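

In this assay, a chloro group on this carbon is the first change shown to bring a reading off the limit, with an at least 2.8-fold lower number from compound 2 to compound 4 (0.45 log units; beyond the scatter) where it replaces hydrogen and an at least 2.8-fold lower number from compound 3 to compound 4 (0.45 log units; beyond the scatter) where it replaces amino. Where the chloro sits also counts, with an at least 2.8-fold lower number from compound 1 to compound 4 (0.45 log units; beyond the scatter) on going from 2-chlorophenyl to 4-chlorophenyl. The steps among compound 1, compound 2 and compound 3 cannot be read, and each new step gives only a minimum size, as those three share one limit: the limit of > 12000 nM in this assay, at which 3 of the 4 values shown sit.

Whether this gain is specific to chloro remains open, as 4-bromophenyl, 4-methylphenyl and 4-methoxyphenyl are not among the compounds shown. Going by these compounds, how far the nitro group on the other ring matters also remains open.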